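The source may hold more compounds than are shown below. What is called first, only, known or untested is meant among the compounds shown, and "the series" means these compounds.

Measured in a functional assay on HCT-116 cells (Homo sapiens), read by MTT assay, with a stated time of 72 h; on this read-out lower numbers stand for stronger inhibition and higher numbers for weaker inhibition:

- Compound 1 `C#Cc1cn([C@@H]2O[C@H](CO)[C@@H](O)[C@H]2O)c2nc(C)nc(N)c12`: > 20000 nM
- Compound 2 `COc1nc(N)nc2c1c(-c1ccco1)cn2[C@@H]1O[C@H](CO)[C@@H](O)[C@H]1O`: > 20000 nM
- Compound 3 `COc1nc(N)nc2c1c(-c1ccoc1)cn2[C@@H]1O[C@H](CO)[C@@H](O)[C@H]1O`: > 20000 nM

Each of these entries is a limit of the assay and not a number. Compound 3 therefore has no exact place on the scale, and the series as a whole stands at the limit of > 20000 nM in this assay, at which 3 of the 3 values shown sit.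

The next compound is compound 4 `C#Cc1cn([C@@H]2O[C@H](CO)[C@@H](O)[C@H]2O)c2nc(N)nc(OC)c12`, which has not yet been measured. The structural change from compound 3 is ethynyl in place of furan-3-yl on an aromatic carbon.

Among the measured compounds shown here, only one measured step bears directly on this position, a step that the two limits leave unreadable from compound 2 to compound 3. It exchanges one furan for another and gives no size to carry over to the new group. Compound 1, which also carries ethynyl, shows a limit of > 20000 nM.

The data thus offer no sign of a gain in this assay, although they cannot exclude one. The most likely outcome is that compound 4 stays at or near the limit, with a measurable value remaining possible. The estimated step is a number no higher from compound 3 to compound 4 (the limit leaves the size open). Compound 4 is expected at 20000 nM, with an estimated range from 5000 nM to 40000 nM.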

Compound 4, half-maximal inhibitory concentration: > 20000 nM
Compound 4: only a limit was reported; the forecaster's own chance of this, stated with the estimate: 75%; the middle value lies on the limit itself.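

In this assay compound 4 gives > 20000 nM, which is a limit of the assay and not a number. The steps from compound 2 and compound 3 to compound 4 therefore cannot be read. The compounds shown leave open whether ethynyl, furan-2-yl and furan-3-yl differ at all in their effect on these cells.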